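Working notes: halogen swap and expected plasma stability

The source may report more compounds than this note shows. Statements on the series, on what has been measured and on what is new or still open speak of the compounds shown alone.

Measured so far in an ADME assay on a cell-free system (plasma, Rattus norvegicus) for metabolic stability; a lower number here means that the compound disappears faster, a higher number that the compound lasts longer:
compound 1, `Cc1nc(N2Nc3onc(-c4ccccc4)c3C2c2ccc(Cl)cc2)sc1/N=N/c1ccccc1`; compound 1 gives 4.42 h
compound 2, `Cc1ccc(/N=N/c2sc(N3Nc4onc(-c5ccccc5)c4C3c3ccc(Cl)cc3)nc2C)cc1`; compound 2 gives 5.72 h
compound 3, `Cc1nc(N2Nc3onc(-c4ccccc4)c3C2c2ccc(Cl)cc2)sc1/N=N/c1ccc(Cl)cc1`; compound 3 gives 7.57 h

Compound 3 stands at the upper end of these three numbers, but both steps leading to it are within the scatter: a 1.7-fold higher number from compound 1 to compound 3 (0.23 log units; within the scatter) and a 1.3-fold higher number from compound 2 to compound 3 (0.12 log units; within the scatter). The first came with chloro in place of hydrogen on an aromatic carbon, the second with chloro in place of methyl on an aromatic carbon; the remaining step, a 1.3-fold higher number from compound 1 to compound 2 (0.11 log units; within the scatter), is also within the scatter.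

Compound 4 is `Cc1nc(N2Nc3onc(-c4ccccc4)c3C2c2ccc(Cl)cc2)sc1/N=N/c1ccc(Br)cc1`. It differs from compound 3 by bromo in place of chloro on an aromatic carbon, a change on the same kind of aromatic carbon as the three steps above. All three of those steps left this assay within the scatter, so no step beyond the scatter is expected here either, in either direction. For compound 4 the expected step is a 1.0-fold lower number from compound 3 to compound 4 (0.00 log units; within the scatter). Compound 4 is therefore estimated at 7.5 h, with a range from 4.5 h to 12.5 h.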

Compound 4, half-life: 4.07 h
Compound 4: the middle estimate sits 1.8-fold (0.27 log units) above what was measured; measured number below the stated range.
By their numbers in this assay, from the lowest: compounds 4, 1, 2 and 3 (each within the scatter of the next).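

Bromo in place of chloro at this position, on an aromatic carbon para to a large group, gives a 1.9-fold lower number from compound 3 to compound 4 (0.27 log units; within the scatter) in this assay, the largest step so far in the series, though still within the scatter. The other new steps, a 1.4-fold lower number from compound 2 to compound 4 (0.15 log units; within the scatter) and a 1.1-fold lower number from compound 1 to compound 4 (0.04 log units; within the scatter), are also within the scatter, so hydrogen, methyl, chloro and bromo at this position cannot be told apart in this assay. No available evidence bears on this result.

The compounds shown leave open whether an amine, a carboxylic acid or a longer chain at this position would produce a step beyond the scatter. As far as these compounds go, whether a change elsewhere on the shared core would do so also remains open.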